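Difluoromethoxy in Place of Anilinomethyl: Expected Stability

The source may hold more compounds than are shown below. What is called first, only, known or untested is meant among the compounds shown, and "the series" means these compounds.

Compound 1 `O=[N+]([O-])c1cn2c(n1)OC[C@@H](OCc1ccc(-c3cccc(OCc4ccccc4)c3)cc1)C2`: 50%
Compound 2 `O=[N+]([O-])c1cn2c(n1)OC[C@@H](OCc1ccc(-c3ccc(CNc4ccccc4)cc3)cc1)C2`: 52%

In an ADME assay on microsomes from liver (Mus musculus, strain CD1) for metabolic stability, read by LC-MS, with a stated time of 1 h (on this read-out lower numbers stand for a less stable compound and higher numbers for a more stable compound), compound 1 gives 50%, and compound 2 gives 52%. These two numbers lie within the scatter of each other, so compound 2 and compound 1 cannot be told apart on this assay.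

Compound 3 `O=[N+]([O-])c1cn2c(n1)OC[C@@H](OCc1ccc(-c3ccc(OC(F)F)cc3)cc1)C2` differs from compound 2 in one place: difluoromethoxy in place of anilinomethyl on an aromatic carbon. Among the compounds with values here, no measured pair shows such a change, so the expectation rests on the two numbers alone. A small upward step of a number 8 percentage points higher from compound 2 to compound 3 (within the scatter) in this assay is expected, hardly beyond the scatter. Compound 3 is therefore estimated at 60%, within 40% to 80%.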

Compound 3, percent of the compound remaining: 77%
Compound 3: middle estimate off by 17 percentage points, on the low side, and the stated range covers the measured number.
By their numbers in this assay, from the lowest: compounds 1 and 2 (each within the scatter of the next); then compound 3.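

In this assay, difluoromethoxy in place of anilinomethyl, on an aromatic carbon para to a large group, gives a number 25 percentage points higher from compound 2 to compound 3 (beyond the scatter), so the number responds to what sits at this position. The change removes a six-membered aromatic ring and a hydrogen-bond donor and brings in fluorine, all in one step. Nothing measured here explains the gain. Which of these differences matters remains open. Methoxy, trifluoromethoxy or aminomethyl at the same position would help to separate them.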